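Mirror-image pair on the cyano analogue in the alpha3/beta4 series

This account rests on a few compounds, and the source may have more. Where it says the series, first, only, none or still open, it means among the compounds named here.

Measured so far in a functional assay on HEK293 cells for agonist activity at Neuronal acetylcholine receptor; alpha3/beta4 (Homo sapiens), read by FLIPR; a higher number here means that more compound is needed for the effect, a lower number that less compound is needed:
compound 1 `c1cncc(N2C[C@@H]3CCNC[C@@H]32)c1` gives 1700 nM
compound 2 `c1cncc(N2C[C@H]3CCNC[C@H]32)c1` gives 1540 nM
compound 3 `N#Cc1cncc(N2C[C@@H]3CCNC[C@@H]32)c1` gives 2560 nM

Among the measured compounds shown here, compound 3 sits at the upper edge of these three numbers, but no gap separates it from the others beyond the usual scatter: the step of a 1.5-fold higher number from compound 1 to compound 3 (0.18 log units; within the scatter) was the only change in substitution, cyano in place of hydrogen on an aromatic carbon, and compound 2 lies about as close.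

Compound 4 `N#Cc1cncc(N2C[C@H]3CCNC[C@H]32)c1` is the untested partner. Its relation to compound 3 is the two compounds have the same atoms and bonds and differ only in configuration as drawn: 2 of 2 stereo elements differ (all stereocentres are inverted: mirror images); a stereocentre at a saturated ring carbon is drawn S in compound 3 and R in compound 4; a stereocentre at a saturated ring carbon is drawn R in compound 3 and S in compound 4, so it asks the same question that the pair of compounds 1 and 2 already answered on the unsubstituted core. There the step of a 1.1-fold lower number from compound 1 to compound 2 (0.04 log units; within the scatter) was flat; the relevant evidence is the fact that compounds 1 and 2 differ only in the configuration as drawn. On that basis no step beyond the scatter is expected from compound 3 to compound 4 in this assay, with at most a slight drift downward as in the earlier pair, a 1.1-fold lower number from compound 3 to compound 4 (0.05 log units; within the scatter).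

Compound 4 is therefore expected to give about 2300 nM, with a likely range from 1200 nM to 4500 nM.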

Compound 4, half-maximal effective concentration: 5560 nM
Compound 4: the middle estimate sits 2.4-fold (0.38 log units) below what was measured; the measured number lies above the stated range.
By their numbers in this assay, from the lowest: compounds 2, 1 and 3 (each within the scatter of the next); then compound 4.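

In this assay, inverting both stereocentres now gives a step beyond the scatter on the cyano-bearing core, a 2.2-fold higher number from compound 3 to compound 4 (0.34 log units; beyond the scatter), whereas the same inversion on the unsubstituted core stayed flat, a 1.1-fold lower number from compound 1 to compound 2 (0.04 log units; within the scatter). Cyano in place of hydrogen on an aromatic carbon also gives its first step beyond the scatter, a 3.6-fold higher number from compound 2 to compound 4 (0.56 log units; beyond the scatter), while its step in the other configuration, a 1.5-fold higher number from compound 1 to compound 3 (0.18 log units; within the scatter), stays within it. These two steps still cannot be told apart, so a dependence of the cyano change on configuration is suggested but not established: the same change on two cores in this assay, a 1.5-fold higher number (0.18 log units; within the scatter) from compound 1 to compound 3 and a 3.6-fold higher number (0.56 log units; beyond the scatter) from compound 2 to compound 4, 2.4-fold (0.38 log units) apart, within the scatter of two such steps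

The compounds shown leave open whether the separation between mirror images belongs to the cyano group alone or also appears with another group on that aromatic carbon, such as an amine, a chlorine or a carboxylic acid. They also leave open whether such a group would bring either configuration below the numbers of compounds 1 and 2.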